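A few compounds are considered here, and "the series" means these few. Any claim that something is new, unique, unknown or untested is made for them only; others in the source may bear on it.

Measured so far in an in vitro ADME assay on microsomes from liver (Homo sapiens) for metabolic stability; on this read-out higher numbers stand for fast clearance and lower numbers for slow clearance:
Compound 1 `CC(C)NC(=O)[C@H]1CC[C@@H](n2/c(=N/C(=O)c3ccc(F)c(F)c3)[nH]c3ccc(CN4CCC(C(C)(C)O)CC4)cc32)CC1` gives 60 mL.min-1.g-1
Compound 2 `CC(C)NC(=O)[C@H]1CC[C@@H](n2/c(=N/C(=O)c3ccc(F)c(Cl)c3)[nH]c3ccc(CN4CCC(C(C)(C)O)CC4)cc32)CC1` gives 83 mL.min-1.g-1

Compound 2 cannot be told apart from compound 1 on these numbers. Compound 3 `CC(C)NC(=O)[C@H]1CC[C@@H](n2/c(=N/C(=O)c3cccnc3)[nH]c3ccc(CN4CCC(C(C)(C)O)CC4)cc32)CC1` carries the change pyridin-3-yl in place of 3-chloro-4-fluorophenyl on a carbonyl carbon in the form of pyridin-3-yl in place of 3-chloro-4-fluorophenyl on a carbonyl carbon. Going by the values given here, the one measured step, a 1.4-fold higher number from compound 1 to compound 2 (0.14 log units; within the scatter) for chloro in place of fluoro, kept the ring in place, so it says little about replacing the whole ring. A lower number is still expected, estimated as a 1.8-fold lower number from compound 2 to compound 3 (0.27 log units; within the scatter) with wide uncertainty. Compound 3 is expected at 45 mL.min-1.g-1 within an estimated range of 20 mL.min-1.g-1 to 95 mL.min-1.g-1 in this assay.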

Compound 3, intrinsic clearance in microsomes: 47 mL.min-1.g-1
The estimate for compound 3 lay 1.0-fold (0.02 log units) below the measured number; low and high end bracket the measured number.
By their numbers in this assay, from the lowest: compounds 3, 1 and 2 (each within the scatter of the next).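

In this assay replacing the whole ring on the carbonyl carbon with pyridin-3-yl gives a 1.8-fold lower number from compound 2 to compound 3 (0.25 log units; within the scatter) and a 1.3-fold lower number from compound 1 to compound 3 (0.11 log units; within the scatter) as its two steps. So at this position, a ring with one hetero atom and no halogen cannot be told apart from either halogenated phenyl ring, a wider change than the earlier swap of one halogen for another. Nothing available here offers an explanation for this result.

Still open, as far as these compounds go, is whether pyridin-4-yl, a saturated ring such as piperidin-4-yl, or a simple methyl group on this carbonyl carbon would move clearance beyond the scatter.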